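From 4-methylpyrimidin-2-yl to ethoxycarbonyl on the amide-type nitrogen

This account rests on a few compounds, and the source may have more. Where it says the series, first, only, none or still open, it means among the compounds named here.

In a toxicity assay on Vero cells (Chlorocebus sabaeus) for cytotoxicity, read by MTT assay (on this read-out lower numbers stand for stronger inhibition and higher numbers for weaker inhibition), compound 2 `Cc1ccnc(NC(=O)c2ccsc2NC(=O)c2ccc(S(=O)(=O)N3CCCCC3)cc2)n1` gives 32.8 ug/mL and compound 3 `Cc1ccnc(NC(=O)c2ccsc2NC(=O)c2ccc(S(=O)(=O)N3CCOCC3)cc2)n1` gives 42.7 ug/mL. Within the data shown here, the step of a 1.3-fold higher number from compound 2 to compound 3 (0.11 log units; within the scatter) lies within the scatter, so compound 2 stands level with the only other number. Compound 1 `O=C(NC(=O)c1ccsc1NC(=O)c1ccc(S(=O)(=O)N2CCCCC2)cc1)OCC(F)(F)F` has no number here, only the entry "nd" (no result reported).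

The next compound to read is compound 4 `CCOC(=O)NC(=O)c1ccsc1NC(=O)c1ccc(S(=O)(=O)N2CCCCC2)cc1`, with ethoxycarbonyl in place of 4-methylpyrimidin-2-yl on an amide-type nitrogen. Among the measured compounds shown here, the single measured step, a 1.3-fold higher number from compound 2 to compound 3 (0.11 log units; within the scatter), concerns a different place, morpholin-4-yl in place of piperidin-1-yl on a sulfonyl sulfur, and bears only indirectly on this change. For the measured compounds named here, it shows a small step, but no measured pair covers the loss of 4-methylpyrimidin-2-yl. Compound 1 also lacks that group but supplies no number. No direction can therefore be supported, and the range must stay wide.

The expected change is a 1.1-fold higher number from compound 2 to compound 4 (0.03 log units; within the scatter), which means no expected move beyond the scatter. For compound 4 the estimated value in this assay is 35 ug/mL, with an expected range of 12 ug/mL to 100 ug/mL.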

Compound 4, half-maximal inhibitory concentration: 18.6 ug/mL
Compound 4: middle estimate off by 1.9-fold (0.27 log units), on the high side; the range from low to high includes it.
By their numbers in this assay, from the lowest: compounds 4, 2 and 3 (each within the scatter of the next, the first and the last beyond it).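

Working from this assay, the amide-type nitrogen is the second place in the series with a readable step: ethoxycarbonyl in place of 4-methylpyrimidin-2-yl gives a 1.8-fold lower number from compound 2 to compound 4 (0.25 log units; within the scatter), and this stays within the scatter. An open chain with no ring therefore stands level with the six-membered aromatic ring here, so for the two compounds compared, that ring is not needed for a number of this size. No available data bear on the reason for this result.

On these data alone, whether a longer chain, such as butoxycarbonyl, or a simple acetyl group on this nitrogen would stay level remains open. Also open, as far as these compounds go, is whether morpholin-4-yl in place of piperidin-1-yl on the sulfonyl sulfur would give a similarly small step with ethoxycarbonyl present.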